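Cyclopropyl quinolone acids: cytotoxicity on V79 cells

The source may hold more compounds than are shown below. What is called first, only, known or untested is meant among the compounds shown, and "the series" means these compounds.

Compound 1 `O=C(O)c1cn(C2CC2)c2cc(N3CCCC3)c(F)cc2c1=O` is the reference. In a functional assay on V79 cells (Cricetulus griseus) for cytotoxicity, read by colony formation (on this read-out higher numbers stand for weaker inhibition and lower numbers for stronger inhibition), compound 1 gives 38 ug/mL. Compound 2 `O=C(O)c1cn(C2CC2)c2c(F)c(N3CCCC3)c(F)cc2c1=O` carries the change fluoro in place of hydrogen on an aromatic carbon and in this assay compound 2 gives 120 ug/mL, a step of a 3.2-fold higher number from compound 1 to compound 2 (0.50 log units; beyond the scatter). Compound 3 `CC1CN(c2cc3c(cc2F)c(=O)c(C(=O)O)cn3C2CC2)CC(C)N1` differs from compound 1 by 3,5-dimethylpiperazin-1-yl in place of pyrrolidin-1-yl on an aromatic carbon. For compound 3 this assay reports only a limit, > 500 ug/mL, which is the limit of > 500 ug/mL in this assay, at which 1 of the 3 values shown sits. The step is an at least 13-fold higher number from compound 1 to compound 3 (1.11 log units; beyond the scatter), so compound 3 stands at the weaker end of what the assay resolves.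

Compound 4 `CC1CN(c2c(F)cc3c(=O)c(C(=O)O)cn(C4CC4)c3c2F)CC(C)N1` is not yet measured. It differs from compound 3 by fluoro in place of hydrogen on an aromatic carbon, the same kind of change as that from compound 1 to compound 2, but here the place is ortho to a 3,5-dimethylpiperazin-1-yl group rather than ortho to a pyrrolidin-1-yl group. The expected step is a step that the limit leaves unreadable from compound 3 to compound 4, resting on a 3.2-fold higher number from compound 1 to compound 2 (0.50 log units; beyond the scatter) and on the limit already reached by compound 3. Compound 4 is therefore estimated at 1000 ug/mL, between 500 ug/mL and 3000 ug/mL, and most probably reported only as a limit.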

Compound 4, half-maximal inhibitory concentration: 150 ug/mL
Beside the measured number, compound 4's estimate is 6.7-fold (0.82 log units) above it, outside the stated range (below it).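

Fluoro in place of hydrogen on an aromatic carbon does not carry over from one core to the other in this assay, since with 3,5-dimethylpiperazin-1-yl in the molecule it gives an at least 3.3-fold lower number from compound 3 to compound 4 (0.52 log units; beyond the scatter), opposite in direction to the step with pyrrolidin-1-yl: the same change on two cores in this assay, a 3.2-fold higher number (0.50 log units; beyond the scatter) from compound 1 to compound 2 and an at least 3.3-fold lower number (0.52 log units; beyond the scatter) from compound 3 to compound 4, at least 10-fold (1.02 log units) apart, beyond the scatter of two such steps

The amine exchange does not carry over either, as with the added fluoro present it gives only a 1.3-fold higher number from compound 2 to compound 4 (0.10 log units; within the scatter), far smaller than the step without that fluoro: the same change on two cores in this assay, an at least 13-fold higher number (1.11 log units; beyond the scatter) from compound 1 to compound 3 and a 1.3-fold higher number (0.10 log units; within the scatter) from compound 2 to compound 4, at least 10-fold (1.02 log units) apart, beyond the scatter of two such steps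

Compound 3 stands only at a limit, > 500 ug/mL, so the steps through it give a direction and a minimum size but no exact size, and these four compounds give no cause for the mismatch and no rule beyond themselves.

Open, on these data alone, is whether the dependence on the amine extends to other amines, for example an unsubstituted piperazin-1-yl or a morpholin-4-yl group. Also open, as far as these compounds go, is whether the methyl groups of the 3,5-dimethylpiperazin-1-yl group or its ring nitrogen matter here.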